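The compounds below may be only part of what the source reports. "The series", "measured", "known", "first", "only" and "open" are said of these compounds alone.

Measured compounds:
compound 1, `CC[C@@H](Nc1c(C#N)c(-c2ccc(-c3ccccc3NC)cc2)nc2cnccc12)C(N)=O`, 2.5
compound 2, `CC[C@H](Nc1c(C#N)c(-c2ccc(Br)cc2)nc2cnccc12)C(N)=O`, 2.3
compound 3, `CCOc1ccccc1-c1ccc(-c2nc3cnccc3c(N[C@H](CC)C(=O)NS(=O)(=O)C3CC3)c2C#N)cc1`, 2.3

In a physicochemical assay for lipophilicity, read by HPLC, at pH 7.5 (on this read-out higher numbers stand for higher lipophilicity and lower numbers for lower lipophilicity), compound 1 gives 2.5, the highest of the three numbers, though both compound 2 and compound 3 lie within the usual scatter of it, so no order among the three can be read from these values. Compound 4, `CC[C@@H](Nc1c(C#N)c(-c2ccc(-c3ccncc3C)cc2)nc2cnccc12)C(N)=O`, has not yet been measured in this assay. It differs from compound 1 in one place: 3-methylpyridin-4-yl in place of 2-(methylamino)phenyl on an aromatic carbon. Within the data shown here, no pair of measured compounds shows this change, so the size of the step rests only on the nature of the change itself. The ring that enters carries a hetero atom in place of one of carbon only, and the hydrogen-bond donor of the methylamino group is lost. On this basis compound 4 is expected to show a step of a number 0.90 log units lower from compound 1 to compound 4 (beyond the scatter), a fall beyond the scatter in this assay. The estimated value for compound 4 is 1.6, with a range from 1.1 to 2.1.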

Compound 4, distribution coefficient: 2
The estimate for compound 4 lay 0.40 log units below the measured number; the measured number falls inside the stated range.
By their numbers in this assay, from the lowest: compounds 4, 2, 3 and 1 (each within the scatter of the next, the first and the last beyond it).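

In this assay, the exchange of 2-(methylamino)phenyl for 3-methylpyridin-4-yl, para to a large group, gives a number 0.50 log units lower from compound 1 to compound 4 (beyond the scatter). This is the only pair shown that differs in one place, so it provides the first direct reading at this position and shows that the number there responds to a change of this group. The exchange alters the ring, which gains a hetero atom, and removes a hydrogen-bond donor, but nothing at hand accounts for the step or divides it between those differences.

The compounds shown leave open whether 2-methylphenyl or unsubstituted pyridin-4-yl at this place would stand with compound 1 or with compound 4. They also leave open whether the same exchange would give a similar step on another of the compounds.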